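The compounds below may be only part of what the source reports. "The series", "measured", "known", "first", "only" and "open" are said of these compounds alone.

Working notes on the series tested in a functional assay on A549 cells (Homo sapiens) for inhibition, read by MTT assay, with a stated time of 24 h; a lower number here means a stronger inhibitor, a higher number a weaker inhibitor. Among the measured compounds shown here, compound 1 `[O-]/[N+](=C\c1cn(CCC(F)(F)C(F)(F)C(F)(F)C(F)(F)C(F)(F)C(F)(F)C(F)(F)C(F)(F)F)nn1)c1ccccc1` is the only member with a numerical read-out: in this assay compound 1 gives 86800 nM. Compound 2 `[O-]/[N+](=C\c1cn(-c2ccccc2)nn1)Cc1ccccc1` reaches only a limit in this assay, namely > 100000 nM. Compound 3 `CCCCCCCCCCn1cc(/C=[N+](\[O-])Cc2ccccc2)nn1` likewise reaches only a limit in this assay, namely > 100000 nM. For the measured compounds named here, compound 1 therefore stands alone as the sole number in the set, while the other two values sit at the limit of > 100000 nM in this assay, at which 2 of the 3 values shown sit. Going by the values given here, no two measured compounds differ in a single place, so no measured step is available.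

Compound 4 `CC(C)(C)/[N+]([O-])=C/c1cn(CCC(F)(F)C(F)(F)C(F)(F)C(F)(F)C(F)(F)C(F)(F)C(F)(F)C(F)(F)F)nn1` remains to be measured. Relative to compound 1 it carries tert-butyl in place of phenyl on a double-bonded nitrogen, tert-butyl in place of phenyl on a double-bonded nitrogen. Among the compounds with values here, with no measured step to draw on, the expected change from compound 1 to compound 4 is none beyond the usual scatter, a 1.1-fold higher number from compound 1 to compound 4 (0.04 log units; within the scatter). In this assay compound 4 is accordingly estimated at 95000 nM, within a range of 45000 nM to 200000 nM, with a fair chance that only a limit is returned.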

Compound 4, half-maximal inhibitory concentration: 30500 nM
Beside the measured number, compound 4's estimate is 3.1-fold (0.49 log units) above it, and the stated range ends above it.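

In this assay, among the compounds shown here, the group on the double-bonded nitrogen is the first place where a change can be read, with tert-butyl in place of phenyl: a 2.8-fold lower number from compound 1 to compound 4 (0.45 log units; beyond the scatter). At this place, with the rest of compound 1 unchanged, an aromatic ring is therefore not required for a measurable read-out, and the ring-free tert-butyl gives the lower number, although the step remains modest. Compound 2 and compound 3 each remain at a limit and add no number to this comparison: the limit of > 100000 nM in this assay, at which 2 of the 4 values shown sit.

Going by these compounds, the trend rests on this single pair, and whether it holds with a different group in place of the fluorinated chain remains open. Also open, on these data alone, is how an isopropyl, a cyclohexyl or an aminoethyl group would read on the double-bonded nitrogen of the core of compound 1.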